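A Tail Exchange on the Weaker of Two Inhibitors

The source may hold more compounds than are shown below. What is called first, only, known or untested is meant among the compounds shown, and "the series" means these compounds.

Of the compounds shown here, two have so far been measured in an assay for inhibition of Fatty-acid amide hydrolase 1 (Rattus norvegicus); a lower number here means a stronger inhibitor, a higher number a weaker inhibitor. Compound 1, `NC(=O)c1cccc(-c2cnc(C(=O)CCc3ccc(-c4ccccc4)cc3)o2)n1`, gives 1.2 nM in this assay. Compound 2, `O=C(CCc1ccc(COc2ccccc2)cc1)c1ncc(-c2cccc(-c3nnn[nH]3)n2)o1`, gives 21 nM in this assay, the higher of the two numbers; the gap between its value and that of compound 1 lies beyond the scatter of repeated measurements, so compound 2 is the weaker inhibitor of the pair. Among the compounds with values here, the two structures differ in more than one place, and no single step between them is known, so the data show only that their values sit far apart.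

Compound 3, `O=C(CCc1ccc(-c2ccccc2)cc1)c1ncc(-c2cccc(-c3nnn[nH]3)n2)o1`, differs from compound 2 in one place: phenyl in place of phenoxymethyl on an aromatic carbon. With this change compound 3 acquires the same tail that compound 1 carries, while keeping the rest of compound 2 unchanged. The step of a 2.3-fold lower number from compound 2 to compound 3 (0.37 log units; beyond the scatter) is therefore expected to move the number downward, by more than the scatter but not all the way to the value of compound 1. For compound 3 the estimate is 9 nM, with a range from 3 nM to 35 nM.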

Compound 3, inhibition constant: 25 nM
The estimate for compound 3 lay 2.8-fold (0.44 log units) below the measured number; the range from low to high includes it.
By their numbers in this assay, from the lowest: compound 1; then compounds 2 and 3 (each within the scatter of the next).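

In this assay, phenyl in place of phenoxymethyl on this aromatic carbon, para to a large group, gives a 1.2-fold higher number from compound 2 to compound 3 (0.08 log units; within the scatter) and thus leaves the two compounds within the scatter of each other, so with 1H-tetrazol-5-yl on the shared core this tail exchange shows no measurable effect at this position. Compound 3 also links compound 1 to the series through a single change, and 1H-tetrazol-5-yl in place of carbamoyl gives a 21-fold higher number from compound 1 to compound 3 (1.32 log units; beyond the scatter) as a large step beyond the scatter, the only such single-place step shown so far. Nothing further is available to explain either step.

The compounds shown leave open how a carboxylic acid or a nitrile on that same aromatic carbon would compare with carbamoyl and 1H-tetrazol-5-yl. They also leave open whether phenoxymethyl and phenyl would remain within the scatter of each other with carbamoyl in place of 1H-tetrazol-5-yl, and whether a longer chain in the tail would behave as these two groups do.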